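The compounds below may be only part of what the source reports. "The series", "measured", "known", "first", "only" and "open" are said of these compounds alone.

Measured so far:
- compound 1, `CC(C)(C)c1ccc(C(=O)Nc2cn3cc(-c4ccccc4)ccc3n2)cc1`: 4.83
- compound 2, `CC(C)(CO)c1ccc(C(=O)Nc2cn3cc(-n4ccnc4)ccc3n2)cc1`: 1.62
- compound 3, `Cc1ccc2nc(NC(=O)c3ccc(C(C)(C)C)cc3)sc2c1`: 5.08

Of the compounds shown here, three have so far been measured in a physicochemical assay for lipophilicity, at pH 7.4; on this read-out lower numbers stand for lower lipophilicity and higher numbers for higher lipophilicity. Among these three numbers compound 1 stands second highest. Its nearest neighbour is compound 3, whose value is a little higher but within the scatter of repeated measurements, so the two cannot be told apart. The furthest is compound 2, whose value is far lower, well beyond the scatter.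

Compound 4 `CC(C)(C)c1ccc(C(=O)Nc2cn3cc(Cl)ccc3n2)cc1` has not yet been measured in this assay. It differs from compound 1 in one place: chloro in place of phenyl on an aromatic carbon. The chloro group that enters is a single heavy atom, whereas the phenyl group that leaves is a ring of six carbons. For the measured compounds named here, no measured pair in this set shows exactly this change, so the size of the step can only be expected, not read off. Since a ring of six carbons is removed and replaced by one chlorine atom, a drop in this assay beyond the scatter is expected, of moderate size, yet leaving compound 4 well above compound 2.

Compound 4 is therefore expected to give about 3.6, somewhere between 3.1 and 4.1, which means an expected step of a number 1.23 log units lower from compound 1 to compound 4 (beyond the scatter).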

Compound 4, distribution coefficient: 4.04
Beside the measured number, compound 4's estimate is 0.44 log units below it; measured number inside the range.
By their numbers in this assay, from the lowest: compound 2; then compound 4; then compounds 1 and 3 (each within the scatter of the next).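

For the compounds shown here, this is the first change in the set that can be read on its own, because compound 1 and compound 4 differ in one place only. In this assay, the position on the aromatic carbon para to a fused ring responds to the swap of phenyl for chloro, with a number 0.79 log units lower from compound 1 to compound 4 (beyond the scatter), so what sits here clearly counts towards the read-out, yet the step is only modest even though a whole six-membered aromatic ring of carbon leaves and a single heavy atom enters. Nothing measured here explains why the step has this size.

One pair cannot separate the loss of the phenyl from the arrival of the chloro, and a plain hydrogen at this position would be needed to tell those two contributions apart. The compounds shown also leave open how far the number would move with an amine or a carboxylic acid on this carbon, and whether the same swap gives a step of similar size on a different core.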